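Cytotoxicity of a thioether analogue following a sulfoxide

The source may report more compounds than this note shows. Statements on the series, on what has been measured and on what is new or still open speak of the compounds shown alone.

Compound 1 `COc1ccc(-c2nc(C[S+]([O-])c3cccc(Cl)c3)nc3ccsc23)cn1` in an ADME assay on cells (Homo sapiens) for cytotoxicity, read by resazurin assay, with a stated time of 5 days; a lower number here means that less compound is tolerated, a higher number that more compound is tolerated: > 50000 nM, which is a limit of the assay and not a number.
Compound 2 `COc1ccc(-c2nc(CS(=O)(=O)c3cccc(Cl)c3)nc3ccsc23)cc1` in this assay: 69000 nM.

Both measured compounds share a core that carries a sulfur-linked chlorinated aryl group on a chain carbon. For compound 1 the assay gives only a limit, and compound 1 sits at the limit of > 50000 nM in this assay, at which 1 of the 2 values shown sits. Within the data shown here, compound 2 differs from compound 1 in more than one place, so no single step between them is counted here; the two values show only that compound 2 is tolerated up to a measured concentration while compound 1 has no measured endpoint in this assay.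

Compound 3 `COc1ccc(-c2nc(CSc3cc(Cl)ccc3Cl)nc3ccsc23)cn1` has not yet been measured. It differs from compound 1 by a group of 9 heavy atoms (6 carbon, 1 sulfur, 2 chlorine; one six-membered aromatic ring of carbon only) in place of a group of 9 heavy atoms (6 carbon, 1 oxygen, 1 sulfur, 1 chlorine; one six-membered aromatic ring of carbon only), on a saturated chain carbon bound to an aromatic carbon. Among the measured compounds shown here, no step between measured compounds is available to anchor this change, so the expected step of an at least 1.2-fold lower number from compound 1 to compound 3 (0.09 log units; that floor lies within the scatter) is small, not beyond the usual scatter, in either direction. Compound 3 is therefore expected to give about 40000 nM in this assay, with a range of 12000 nM to 100000 nM, and a fair chance that the assay again reports only a limit.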

Compound 3, half-maximal cytotoxic concentration: > 50000 nM
Compound 3: only a limit was reported (the forecaster's own chance of this, stated with the estimate: 45%); middle value at least 1.2-fold (0.09 log units) from the limit.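

In this assay, among these compounds, compound 1 and compound 3 are both reported only as a limit and not as a number, so no step between them can be read: the limit of > 50000 nM in this assay, at which 2 of the 3 values shown sit. The compounds shown leave open whether the (2,5-dichlorophenyl)sulfanyl group of compound 3 changes the tolerated concentration relative to the group it replaces in compound 1.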